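This account rests on a few compounds, and the source may have more. Where it says the series, first, only, none or still open, it means among the compounds named here.

Measured so far:
compound 1, `COc1cc(OC)c(OC)cc1/C=C/COC(=O)/C=C/c1ccc(OC)c(OC)c1OC`: 25%
compound 2, `COc1cc(OC)c(OC)cc1/C=C/COC(=O)/C=C/c1ccc(F)cc1`: 0%

In a functional assay on the whole organism (strain Kunming) with Mus musculus as the target, with a stated time of 0.5 h, at a dose of 300 mg/kg by the intraperitoneal route (on this read-out higher numbers stand for a weaker effect at the one dose given and lower numbers for a stronger effect), compound 1 gives 25%, and compound 2 gives 0%. Compound 2 thus holds the lowest of the two numbers; its nearest neighbour, compound 1, stands higher by a gap that is beyond the scatter. Among the measured compounds shown here, no pair of the measured compounds differs in a single place, so no step between measured compounds is on record.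

Compound 3, `COc1cc(OC)c(OC)cc1/C=C/COC(=O)/C=C/c1ccc(Br)cc1`, is not yet measured in this assay. It differs from compound 2 as follows: bromo in place of fluoro on an aromatic carbon. For the measured compounds named here, nothing among the measured compounds shows what this exchange does in this assay. The step expected here is small, a number 10 percentage points higher from compound 2 to compound 3 (within the scatter), upward if anything, and quite possibly not beyond the scatter. Compound 3 is estimated at 10% in this assay, within a range from 0% to 35%.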

Compound 3, a percentage reported as activity, at one dose (the size of the read-out at that dose, not a potency): 25%
The estimate for compound 3 lay 15 percentage points below the measured number, within the range that was stated.
By their numbers in this assay, from the lowest: compound 2; then compounds 1 and 3 (each within the scatter of the next).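

In this assay, among the compounds shown here, bromo in place of fluoro on an aromatic carbon, para to a large group, gives a number 25 percentage points higher from compound 2 to compound 3 (beyond the scatter) and supplies the first single-place comparison. This position is therefore not indifferent to the identity of the halogen, and the fluoro compound, compound 2, carries the stronger effect at the one dose given. Nothing on record explains this step.

Going by these compounds, whether chloro, an amine or a methoxy group at this place would read like fluoro or like bromo remains open, as does the result of an unsubstituted phenyl ring. Also unresolved is whether the same exchange would produce a similar step with other substituents on the opposite aromatic ring, and a single dose gives no measure of potency for either compound.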